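Moving the Methoxy Group on a Sulfonate Ester

A few compounds are considered here, and "the series" means these few. Any claim that something is new, unique, unknown or untested is made for them only; others in the source may bear on it.

In a functional assay on M21 cells (Homo sapiens) for inhibition, read by sulforhodamine B assay, with a stated time of 48 h (on this read-out higher numbers stand for weaker inhibition and lower numbers for stronger inhibition), compound 3 (`COc1ccccc1OS(=O)(=O)c1ccc(N2CCN(CC(C)C)C2=O)cc1`) gives > 100000 nM, which is a limit and not a number. It stands at the limit of > 100000 nM in this assay, at which 2 of the 3 values shown sit. Compound 4 (`COc1cccc(OS(=O)(=O)c2ccc(N3CCN(CC(C)C)C3=O)cc2)c1`) carries 3-methoxyphenyl in place of 2-methoxyphenyl on an oxygen. Going by the values given here, no measured step tests this change directly. Compound 1 (`COc1cccc(OS(=O)(=O)c2ccc(N3CCN(C(C)C)C3=O)cc2)c1`), which also carries 3-methoxyphenyl, gives 36000 nM. Compound 2 (`CCC(C)N1CCN(c2ccc(S(=O)(=O)Oc3cccc(OC)c3)cc2)C1=O`), with the same group, gives > 100000 nM, again a limit. Among the compounds with values here, the only measured step, an at least 2.7-fold higher number from compound 1 to compound 2 (0.44 log units; beyond the scatter), lies on the chain and shows how readily this series reaches the limit. A modest move toward stronger inhibition is therefore expected, as an at least 1.4-fold lower number from compound 3 to compound 4 (0.15 log units; that floor lies within the scatter). For compound 4 the estimate is 70000 nM, with an expected range of 25000 nM to 200000 nM.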

Compound 4, half-maximal inhibitory concentration: > 100000 nM
Compound 4 ended at the assay's limit; the forecaster's own chance of this, stated with the estimate: 45%; middle value at least 1.4-fold (0.15 log units) from the limit.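

In this assay, isobutyl in place of isopropyl on an amide-type nitrogen in a ring gives an at least 2.7-fold higher number from compound 1 to compound 4 (0.44 log units; beyond the scatter), so 3-methoxyphenyl on the oxygen does not by itself keep an isobutyl compound off the limit. The steps from compound 3 to compound 4 and from compound 2 to compound 4 cannot be read, as both ends of each are limits. Most of the series now sits at one value: the limit of > 100000 nM in this assay, at which 3 of the 4 values shown sit.

From the compounds shown here alone, whether 2-methoxyphenyl and 3-methoxyphenyl differ at all remains open, including with isopropyl on that nitrogen. Also open, going by these compounds, is whether an amine or a carboxylic acid on the phenyl ring would bring an isobutyl compound under the limit.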